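Opening the ring of compound 2 to give compound 4

The source may report more compounds than this note shows. Statements on the series, on what has been measured and on what is new or still open speak of the compounds shown alone.

Measured so far in a functional assay on NCI-H460 cells (Homo sapiens) for inhibition, read by MTT assay, with a stated time of 24 h, tested at 100 ug/mL; a higher number here means more inhibition of growth at the concentration tested, a lower number less inhibition of growth:
- compound 1 (`CC(=O)SCCC(CCCCC(=O)O)SC(C)=O`): 11%
- compound 2 (`O=C(CCCCC1CCSS1)Nc1cccc2ccccc12`): "not active" (no number reported)
- compound 3 (`O=C(CCCCC(S)CCS)Nc1ccc(Cl)cn1`): 55.8%

In this assay compound 2 stands without a number, reported only as "not active" (no number reported), so no gap to the other two compounds can be sized. Compound 4 (`O=C(CCCCC(S)CCS)Nc1cccc2ccccc12`) has not yet been measured. The structural change to judge is a group of 5 heavy atoms (3 carbon, 2 sulfur; no ring) in place of a group of 5 heavy atoms (3 carbon, 2 sulfur; one five-membered non-aromatic ring with 2 hetero atoms), on a saturated chain carbon, four bonds along the chain from a carbonyl carbon. The five-membered ring leaves, and an open 1,3-disulfanylpropyl group enters on the same chain carbon.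

For the measured compounds named here, no measured pair shows this change on its own, so any forecast is indirect. The closest guide is compound 3, which carries the same 1,3-disulfanylpropyl group and gives 55.8% in this assay. Its amide end differs from that of compound 4, which adds uncertainty. A rise beyond the usual scatter is therefore expected, from no reported activity to a clear reading. For compound 4 the estimated value is 48%, with an expected range from 22% to 75%.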

Compound 4, percent growth inhibition at one concentration: 2.18%
Beside the measured number, compound 4's estimate is 45.8 percentage points above it; measured number outside the range, below it.
By their numbers in this assay, from the lowest: compounds 4 and 1 (each within the scatter of the next); then compound 3.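

For the compounds shown here, compound 2 has only a "not active" report and no number, while compound 4 gives 2.18%, so no step between them can be read in this assay. The compounds shown leave open whether opening the ring changes growth inhibition at all. No supporting data bear on this result.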